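Swapping a phenyl for piperidinylmethyl in a quinazoline series

A few compounds are considered here, and "the series" means these few. Any claim that something is new, unique, unknown or untested is made for them only; others in the source may bear on it.

The shared core of this small set is the same in each member, and the question is what a single change at one arm does to activity. Compound 1 `COc1cc2nc(NCc3ccccc3)nc(NC3CCCCCC3)c2cc1OC` is the starting point. Among the compounds with values here, in an in vitro functional assay on B300-19 cells for antagonist activity at C-C chemokine receptor type 4 (Homo sapiens), read by GTPgammaS binding, tested at 1 uM (on this read-out higher numbers stand for more inhibition at the one concentration tested (going by the name of the read-out) and lower numbers for less inhibition), compound 1 gives 13%, the only plain number in the set. Compound 2 `COc1cc2nc(N3CCC(N4CCCC4)CC3)nc(N(C)C)c2cc1OC` is built differently at two arms of the core. In this assay compound 2 gives < 0%, which is a limit of the assay and not a number; the limit of < 0% in this assay, at which 1 of the 2 values shown sits, shows how many of the values sit there.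

Compound 3 `COc1cc2nc(NCCN3CCCCC3)nc(NC3CCCCCC3)c2cc1OC` is compound 1 with one change: (piperidin-1-yl)methyl in place of phenyl on a saturated chain carbon bound to a nitrogen on an aromatic ring. Within the data shown here, no measured pair shows such a change in this set, so the size of the step must be guessed. The step of a number 2 percentage points higher from compound 1 to compound 3 (within the scatter) is expected to stay near the scatter, because compound 1 itself gives only 13%, leaving little room to fall. Compound 3 is expected to give about 15%, within 0% to 40%.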

Compound 3, a percentage reported as inhibition, at one concentration (the size of the read-out at that concentration, not a potency): 1%
Estimate against measurement, compound 3: 14 percentage points above, and the stated range covers the measured number.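

In this assay, swapping phenyl for (piperidin-1-yl)methyl gives a number 12 percentage points lower from compound 1 to compound 3 (beyond the scatter). Within the data shown here, this is the first measured change at this arm, and it shows that what the arm carries does matter, even in a compound with little inhibition to lose. The step is modest and rests on a single pair, and nothing measured here gives a reason for it.

The compounds shown leave open whether the loss follows from phenyl leaving or from the ring nitrogen of the piperidine arriving, and a cyclohexylmethyl group, which keeps a six-membered ring of carbon only without the aromatic character, would help separate the two. Also open, as far as these compounds go, is how a morpholine ring or a longer chain between the amino nitrogen and the ring would fare at this same place.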